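Amide aryl swap at the carbonyl of compound 1

A few compounds are considered here, and "the series" means these few. Any claim that something is new, unique, unknown or untested is made for them only; others in the source may bear on it.

Measured so far in a functional assay on T47D cells (Homo sapiens) for inhibition, read by sulforhodamine B assay, with a stated time of 48 h, tested at 10 uM; on this read-out higher numbers stand for a weaker effect at the one concentration tested and lower numbers for a stronger effect:
- compound 1 `COc1cc(Cl)cc(-c2nn(-c3cccc(NC(=O)c4ccc(Cl)c(Cl)c4)c3)cc2-c2ccncc2)c1`: 63.2%
- compound 2 `O=C(Nc1cccc(-n2cc(-c3ccncc3)c(-c3cc(O)cc(Cl)c3)n2)c1)Nc1ccc(Cl)c(Cl)c1`: -5.53%
- compound 3 `COc1cc(Cl)cc(-c2nn(-c3cccc(NC(=O)Nc4ccc(Cl)c(Cl)c4)c3)cc2-c2ccncc2)c1`: 18.6%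

Compound 1 stands highest of the three numbers, that is, weakest on this read-out. Its nearest neighbour is compound 3, reached by the step of a number 44.6 percentage points lower from compound 1 to compound 3 (beyond the scatter), and compound 2 lies further off still. The other measured step, a number 24.1 percentage points higher from compound 2 to compound 3 (beyond the scatter), concerns the oxygen on the aromatic ring and leaves the amide side untouched.

Compound 4 `COc1cc(Cl)cc(-c2nn(-c3cccc(NC(=O)c4cccc(C(F)(F)F)c4)c3)cc2-c2ccncc2)c1` differs from compound 1 in one place: 3-(trifluoromethyl)phenyl in place of 3,4-dichlorophenyl on a carbonyl carbon. Neither measured step bears directly on this change. The step from compound 1 to compound 3 does touch the carbonyl carbon, but it replaces the aryl group by an arylamino group rather than exchanging one aryl for another, so its large size cannot be carried over. The step from compound 2 to compound 3 lies elsewhere in the molecule. For the measured compounds named here, with no comparable pair in hand, the expectation for compound 4 in this assay is a step of no clear direction and probably within the scatter, a number 3.2 percentage points lower from compound 1 to compound 4 (within the scatter). Compound 4 is therefore estimated at 60%, with a range from 35% to 85%.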

Compound 4, a percentage reported as activity, at one concentration (the size of the read-out at that concentration, not a potency): 36.6%
Beside the measured number, compound 4's estimate is 23.4 percentage points above it; the range from low to high includes it.
By their numbers in this assay, from the lowest: compound 2; then compound 3; then compound 4; then compound 1.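

In this assay, the aryl group on the carbonyl carbon proves to be a position that responds on its own: a number 26.6 percentage points lower from compound 1 to compound 4 (beyond the scatter), so exchanging one aryl for another, with no arylamino group brought in, already moves the read-out beyond the scatter. That exchange does not match the arylamino compound, however: a number 18 percentage points higher from compound 3 to compound 4 (beyond the scatter), which leaves compound 4 with the weaker effect at the one concentration tested and shows that the aryl exchange and the arylamino replacement are not interchangeable at this carbonyl carbon. Nothing at hand accounts for either step.

The swap removes 3,4-dichlorophenyl and brings in 3-(trifluoromethyl)phenyl as a whole, so these compounds do not separate the loss of the two chlorines from the gain of the trifluoromethyl, and an unsubstituted phenyl or a phenyl carrying a carboxylic acid on that carbonyl carbon would test how far the position tolerates other groups. Also open, from the compounds shown here alone, is whether hydrogen in place of methyl on the oxygen, a change seen so far only with the arylamino compounds, would act the same way on compound 4.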